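The source may hold more compounds than are shown below. What is called first, only, known or untested is meant among the compounds shown, and "the series" means these compounds.

Measured compounds and their numbers in a functional assay on KB cells (Homo sapiens) for cytotoxicity; a higher number here means that more compound is needed for the effect, a lower number that less compound is needed:
compound 1 `CCC[C@@H](OC(C)=O)C1=C(Br)/C(=C/Br)OC1=O` gives 2.1 ug/mL;
compound 2 `CCC[C@@H](OC(C)=O)C1=C(Br)C(=C(Br)Br)OC1=O` gives 0.5 ug/mL;
compound 3 `CCC[C@@H](O)C1=C(Br)C(=C(Br)Br)OC1=O` gives 0.6 ug/mL.

Compound 1 stands highest of the three in this assay; compound 2 and compound 3 both sit beyond the scatter below it, while the gap between those two is within the scatter.

Compound 4 `CCC[C@@H](O)C1=C(Br)/C(=C/Br)OC1=O` is not yet measured. It differs from compound 1 in one place: hydrogen in place of acetyl on an oxygen on a saturated carbon. Within the data shown here, one measured step bears on this exchange, made on the shared core with an extra bromine: a 1.2-fold higher number from compound 2 to compound 3 (0.08 log units; within the scatter). Nothing there points to a shift beyond the scatter, so in this assay the expected step is a 1.1-fold higher number from compound 1 to compound 4 (0.06 log units; within the scatter). Compound 4 is therefore estimated at 2.4 ug/mL, with a range from 1.1 ug/mL to 5 ug/mL.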

Compound 4, concentration for half-maximal effect: 3.4 ug/mL
Estimate against measurement, compound 4: 1.4-fold (0.15 log units) below; the measured number falls inside the stated range.
By their numbers in this assay, from the lowest: compounds 2 and 3 (each within the scatter of the next); then compounds 1 and 4 (each within the scatter of the next).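

In this assay, acetoxy to hydroxy now has a reading on the core of compound 1 as well, with a 1.6-fold higher number from compound 1 to compound 4 (0.21 log units; within the scatter). The exchange therefore stays within the scatter on both cores, with or without the extra bromine: the same change on two cores in this assay, a 1.2-fold higher number (0.08 log units; within the scatter) from compound 2 to compound 3 and a 1.6-fold higher number (0.21 log units; within the scatter) from compound 1 to compound 4, 1.3-fold (0.13 log units) apart, within the scatter of two such steps. On these two cores, the acetyl on this oxygen can be removed with no shift beyond the scatter.

On these data alone, it remains open whether the number would hold with a benzoyl group on this oxygen, or with an amine in place of the oxygen. As far as these compounds go, the opposite configuration at the saturated carbon also remains open.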